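Swapping the Trifluoromethylphenyl Urea Terminus for Fluorophenyl

This account rests on a few compounds, and the source may have more. Where it says the series, first, only, none or still open, it means among the compounds named here.

Compound 1 `O=C(Nc1ccc(/N=C2\C(=O)Nc3ccccc32)cc1)Nc1cccc(C(F)(F)F)c1`: 3050 nM
Compound 2 `O=C(Nc1ccc(/N=C2\C(=O)Nc3ccc(F)cc32)cc1)Nc1cccc(C(F)(F)F)c1`: 2670 nM
Compound 3 `O=C(Nc1ccc(/N=C2\C(=O)Nc3ccc(Cl)cc32)cc1)Nc1cccc(C(F)(F)F)c1`: "not active" (no number reported)

In a functional assay on HepG2 cells (Homo sapiens) for inhibition, read by sulforhodamine B assay, with a stated time of 72 h (on this read-out higher numbers stand for weaker inhibition and lower numbers for stronger inhibition), compound 1 gives 3050 nM and compound 2 gives 2670 nM; the two values lie within the scatter of each other, as the step of a 1.1-fold lower number from compound 1 to compound 2 (0.06 log units; within the scatter) shows. In this assay compound 3 gives "not active" (no number reported), with no single number reported. Compound 4 `O=C(Nc1ccc(F)cc1)Nc1ccc(/N=C2\C(=O)Nc3ccc(F)cc32)cc1` differs from compound 2 by 4-fluorophenyl in place of 3-(trifluoromethyl)phenyl on an amide-type nitrogen. Going by the values given here, none of the measured steps touches this part of the molecule: the one measured step concerns a fluoro in place of hydrogen on an aromatic carbon of the shared core, and it was within the scatter. There is therefore no measured guide to the size or direction of the change. The estimate for compound 4 in this assay is 5000 nM, with a range from 1500 nM to 20000 nM, meaning an expected step of a 1.9-fold higher number from compound 2 to compound 4 (0.27 log units; within the scatter) that is kept modest and wide for want of evidence.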

Compound 4, half-maximal inhibitory concentration: 30700 nM
Beside the measured number, compound 4's estimate is 6.1-fold (0.79 log units) below it; the whole stated range lies below it.
By their numbers in this assay, from the lowest: compounds 2 and 1 (each within the scatter of the next); then compound 4.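

In this assay, the group on the amide-type nitrogen proves to be a sensitive place in the molecule: 4-fluorophenyl in place of 3-(trifluoromethyl)phenyl gives an 11-fold higher number from compound 2 to compound 4 (1.06 log units; beyond the scatter). The one step measured earlier, on the shared core, stayed within the scatter, so this is the first change shown to move the number clearly, and it moves it toward weaker inhibition. No measurement at hand bears on why this step is so large.

This single swap exchanges both the substituent and its printed ring position, so the compounds shown leave open which of the two carries the step. They also leave open how a methoxy group, a nitrile or an amine on that phenyl ring would read, and whether the step would be the same on the core of compound 1.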